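The compounds below may be only part of what the source reports. "The series", "measured", "known", "first", "only" and "open" are said of these compounds alone.

Working notes on the series.

Compound 3 `Cc1cc(-c2sc(Cc3ccc(Cl)cc3)nc2C)ccc1C(N)=O` gives 210 nM in a functional assay on cells for agonist activity at G-protein coupled receptor 52 (Homo sapiens), read by AlphaScreen and cAMP accumulation, with a stated time of 30 min; a higher number here means that more compound is needed for the effect, a lower number that less compound is needed. Among the three measured compounds it stands second highest, with compound 2 `Cc1cc(-c2sc(Cc3cccc(F)c3)nc2C)ccc1C(N)=O` nearest at 260 nM and compound 1 `COc1cccc(Cc2nc(C)c(-c3ccc(C(N)=O)c(C)c3)s2)c1` furthest at 160 nM; both gaps are within the scatter, so no order among the three can be claimed.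

The next compound, compound 4 `Cc1cc(-c2sc(Cc3cc(F)cc(Cl)c3)nc2C)ccc1C(N)=O`, differs from compound 3 in one place: 3-chloro-5-fluorophenyl in place of 4-chlorophenyl on a saturated chain carbon bound to an aromatic carbon. For the measured compounds named here, the steps that bear on this are those that alter the same aryl group on the saturated chain carbon: a 1.3-fold higher number from compound 1 to compound 3 (0.12 log units; within the scatter) and a 1.2-fold lower number from compound 2 to compound 3 (0.09 log units; within the scatter), with the related 1.6-fold higher number from compound 1 to compound 2 (0.21 log units; within the scatter). All three are within the scatter, so the measured data give no sign that exchanging substituents on this aryl group moves the number beyond the scatter.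

For compound 4 the step of a 1.1-fold higher number from compound 3 to compound 4 (0.04 log units; within the scatter) is therefore expected to stay within the scatter. The estimate for compound 4 in this assay is 230 nM, with a range from 100 nM to 550 nM.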

Compound 4, half-maximal effective concentration: 25 nM
Estimate against measurement, compound 4: 9.2-fold (0.96 log units) above; measured number outside the range, below it.
By their numbers in this assay, from the lowest: compound 4; then compounds 1, 3 and 2 (each within the scatter of the next).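

Among the changes to the aryl group on the saturated chain carbon, 3-chloro-5-fluorophenyl gives the first steps beyond the scatter, against 4-chlorophenyl (an 8.4-fold lower number from compound 3 to compound 4 (0.92 log units; beyond the scatter)) and against 3-methoxyphenyl (a 6.4-fold lower number from compound 1 to compound 4 (0.81 log units; beyond the scatter)). For the compounds shown here, the cleanest comparison is a single change, chloro in place of hydrogen on an aromatic carbon (a 10-fold lower number from compound 2 to compound 4 (1.02 log units; beyond the scatter)), so this aryl group is sensitive to substitution in a way the earlier compounds, all within the scatter of one another, did not reveal. No measured evidence bears on why this change has such an effect.

The compounds shown do not tell whether the fluoro is needed alongside the chloro, or whether a second chloro in its place would hold the low number. Also open, from the compounds shown here alone, is how a trifluoromethyl, nitrile or amine would fare in place of the chloro.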